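Esters of the shared core: nitro for methyl

The source may hold more compounds than are shown below. What is called first, only, known or untested is meant among the compounds shown, and "the series" means these compounds.

Three esters of a common core have been measured in a functional assay on the whole organism with Mus musculus as the target; on this read-out lower numbers stand for lower potency and higher numbers for higher potency (the scale is a negative logarithm). Compound 1 `CN1CCC(OC(=O)c2ccccc2F)CC1` gives 1.41. Compound 2 `COc1ccccc1C(=O)OC1CCN(C)CC1` gives 1.43. Compound 3 `Cc1ccc(C(=O)OC2CCN(C)CC2)cc1` gives 1.17. Going by the values given here, the one single-point step among them, a number 0.02 log units higher from compound 1 to compound 2 (within the scatter), is within the scatter, and the values of compound 3 lie within the scatter of both compound 1 and compound 2, so no ordering among the three can be read from these numbers.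

Compound 4 `CN1CCC(OC(=O)c2ccc([N+](=O)[O-])cc2)CC1` has not yet been measured. It differs from compound 3 as follows: nitro in place of methyl on an aromatic carbon. The group that leaves is methyl and the group that enters is nitro, on an aromatic carbon of a six-membered aromatic ring of carbon only.

Among the compounds with values here, no measured step changes a group on that position of the ring, so nothing here bears directly on the exchange. Within the data shown here, the only comparable substituent exchange on an aromatic carbon is a number 0.02 log units higher from compound 1 to compound 2 (within the scatter), which was within the scatter. On this basis no step beyond the scatter is expected in this assay, and the estimated step is a number 0.13 log units higher from compound 3 to compound 4 (within the scatter). Compound 4 is therefore estimated at 1.3, with a range from 0.9 to 1.75.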

Compound 4, logarithm of the reciprocal of the active concentration, log(1/C): 1.14
Estimate against measurement, compound 4: 0.16 log units above; low and high end bracket the measured number.
By their numbers in this assay, from the lowest: compounds 4, 3, 1 and 2 (each within the scatter of the next).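

Nitro in place of methyl on an aromatic carbon para to a large group gives the first measured step at this position: in this assay, the exchange gives a number 0.03 log units lower from compound 3 to compound 4 (within the scatter), so compound 3 and compound 4 cannot be told apart on this read-out. The earlier step concerned only fluoro and methoxy in another place on the ring, so it said nothing about this position; here, the two groups compared differ in composition and size, and nitro brings hydrogen-bond acceptors that methyl lacks, yet the result stays within the scatter. For this pair, then, those differences in atoms and acceptor count come with no readable step, and no measurement bearing on a cause accompanies the result.

On these data alone, with only methyl and nitro represented at this position, it remains open whether an amine, a carboxylic acid or a longer chain such as butoxy on the same aromatic carbon would give a step beyond the scatter. As far as these compounds go, whether nitro for methyl would read the same way at another position of the ring also remains open.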